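The source may hold more compounds than are shown below. What is called first, only, known or untested is meant among the compounds shown, and "the series" means these compounds.

Measured so far:
compound 1 `CC(C(=O)NCc1ccc(C(F)(F)Cl)nc1N1CCCCC1)c1ccc(NS(C)(=O)=O)c(F)c1`, which in an assay on CHO cells for antagonist activity at transient receptor potential cation channel subfamily V member 1 (Homo sapiens), read by FLIPR (on this read-out lower numbers stand for stronger inhibition and higher numbers for weaker inhibition), gives 1.3 nM
compound 2 `CC(C(=O)NCc1ccc(C2CC2)nc1N1CCCCC1)c1ccc(NS(C)(=O)=O)c(F)c1`, which in this assay gives 1.1 nM

Among the measured compounds shown here, of the two numbers, compound 1 has the higher one; the single step of a 1.2-fold lower number from compound 1 to compound 2 (0.07 log units; within the scatter) lies within the scatter. Compound 3 `CC(C(=O)NCc1ccc(C(F)(F)Cl)nc1N1CCCCCC1)c1ccc(NS(C)(=O)=O)c(F)c1` is derived from compound 1 by azepan-1-yl in place of piperidin-1-yl on an aromatic carbon. For the measured compounds named here, no measured step concerns this ring; the only measured step concerns another position and stays within the scatter. Therefore no step beyond the scatter is expected in this assay. For compound 3 the estimated value is 1.5 nM, with a range from 0.5 nM to 5 nM, so that a 1.2-fold higher number from compound 1 to compound 3 (0.06 log units; within the scatter) is expected.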

Compound 3, inhibition constant: 0.5 nM
Beside the measured number, compound 3's estimate is 3.0-fold (0.48 log units) above it; the range from low to high includes it.
By their numbers in this assay, from the lowest: compound 3; then compounds 2 and 1 (each within the scatter of the next).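

In this assay, among the compounds shown here, the position next to the ring nitrogen is the first to show a step beyond the scatter: azepan-1-yl in place of piperidin-1-yl gives a 2.6-fold lower number from compound 1 to compound 3 (0.41 log units; beyond the scatter), a modest gain, whereas the change at the other position stayed within the scatter. The seven-membered ring is therefore accepted here, with no loss against the six-membered one. Nothing available explains this step.

Open, from the compounds shown here alone, is whether an open-chain diethylamino group or a morpholin-4-yl ring would hold at this place. Also open, going by these compounds, is whether azepan-1-yl gives a similar step alongside the cyclopropyl group of compound 2.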